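Hydroxyurea amides and cyclic imides tested on leukaemia cells

A few compounds are considered here, and "the series" means these few. Any claim that something is new, unique, unknown or untested is made for them only; others in the source may bear on it.

Compound 1, `CC(C)C(NC(=O)NO)C(=O)NC1CCCCC1`, in a functional assay on CCRF-CEM cells (Homo sapiens) for inhibition; on this read-out lower numbers stand for stronger inhibition and higher numbers for weaker inhibition: > 100000 nM (a limit of the assay, not a number).
Compound 2, `CCC(C)C(NC(=O)NO)C(=O)NC1CCCCC1`, in this assay: 153000 nM.
Compound 3, `CCC(C)C1NC(=O)N(C2CCCC2)C1=O`, in this assay: > 200000 nM (a limit of the assay, not a number).

Compound 2 is the only one of the three measured compounds that gives a number in this assay. For compound 1 the result is a limit, (the limit of > 100000 nM in this assay, at which 1 of the 3 values shown sits). Compound 1 differs from compound 2 by hydrogen in place of methyl on a saturated chain carbon, three bonds along the chain from an amide-type nitrogen and a carbonyl carbon; the step that the limit leaves unreadable from compound 2 to compound 1 cannot be read because compound 1 sits at the limit.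

Compound 3 has a different core from compound 2, and the difference between the two cores is not broken down here. For compound 3, too, only a limit is known in this assay, (the limit of > 200000 nM in this assay, at which 1 of the 3 values shown sits).

Compound 4, `CC(C)C1NC(=O)N(C2CCCC2)C1=O`, has not yet been measured. It differs from compound 3 by hydrogen in place of methyl on a saturated chain carbon, two bonds along the chain from a saturated ring carbon. This is the same kind of change as that from compound 2 to compound 1, but the place is not the same word for word: in compound 1 the carbon is three bonds along the chain from an amide-type nitrogen and a carbonyl carbon, whereas in compound 4 it is two bonds along the chain from a saturated ring carbon. The earlier step of this kind is unreadable, so its size gives no guide. Compound 3 is at a limit, and compound 4 is expected to stay at or near a limit as well, with an expected step that the limit leaves unreadable from compound 3 to compound 4. The estimate for compound 4 in this assay is 300000 nM, between 150000 nM and 1000000 nM.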

Compound 4, half-maximal inhibitory concentration: > 200000 nM
Compound 4: a limit, no number (the forecaster's own chance of this, stated with the estimate: 85%); the middle value does not contradict the limit.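

In this assay compound 4 stays at a limit, as compound 3 does, so no step between compound 3 and compound 4 can be read: the limit of > 200000 nM in this assay, at which 2 of the 4 values shown sit.

The compounds shown leave open whether hydrogen in place of methyl changes inhibition at all, and how strongly compound 1, compound 3 and compound 4 inhibit, as compound 2 alone gives a number.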